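Notes on the aminophenyl shift across two related cores

The source may hold more compounds than are shown below. What is called first, only, known or untested is meant among the compounds shown, and "the series" means these compounds.

Compound 1 `Nc1ccc(Nc2nc3ccccc3nc2S(=O)(=O)c2ccccc2)cc1` gives 10800 nM in a functional assay on HCT-116 cells (Homo sapiens) for cytotoxicity, read by MTT assay, with a stated time of 72 h; a lower number here means a stronger inhibitor, a higher number a weaker inhibitor. Compound 2 `Nc1cccc(Nc2nc3ccccc3nc2S(=O)(=O)c2ccccc2)c1` differs by 3-aminophenyl in place of 4-aminophenyl on a nitrogen on an aromatic ring and gives 1540 nM in this assay; the step is a 7.0-fold lower number from compound 1 to compound 2 (0.85 log units; beyond the scatter). Compound 3 `Cc1ccc(S(=O)(=O)c2nc3ccccc3nc2Nc2ccc(N)cc2)cc1` carries a core that differs from that of compound 1 by methyl in place of hydrogen on an aromatic carbon; in this assay compound 3 gives 11500 nM, and the step of a 1.1-fold higher number from compound 1 to compound 3 (0.03 log units; within the scatter) shows the two cores behaving without a noticeable difference. Compound 4 `Cc1ccc(S(=O)(=O)c2nc3ccccc3nc2Nc2cccc(N)c2)cc1` is not yet measured and differs from compound 3 by 3-aminophenyl in place of 4-aminophenyl on a nitrogen on an aromatic ring, the same change as from compound 1 to compound 2, at a place described in identical words. The expectation rests on that single earlier step and on the two cores reading alike. The expected step is a 6.8-fold lower number from compound 3 to compound 4 (0.83 log units; beyond the scatter), about as large as a 7.0-fold lower number from compound 1 to compound 2 (0.85 log units; beyond the scatter). Compound 4 is therefore estimated at 1700 nM in this assay, expected between 700 nM and 4500 nM.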

Compound 4, half-maximal inhibitory concentration: 2390 nM
Compound 4: the middle estimate sits 1.4-fold (0.15 log units) below what was measured; measured number inside the range.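

In this assay the change from 4-aminophenyl to 3-aminophenyl carries over to the core of compound 3, where it gives a 4.8-fold lower number from compound 3 to compound 4 (0.68 log units; beyond the scatter) and matches the earlier step: the same change on two cores in this assay, a 7.0-fold lower number (0.85 log units; beyond the scatter) from compound 1 to compound 2 and a 4.8-fold lower number (0.68 log units; beyond the scatter) from compound 3 to compound 4, 1.5-fold (0.16 log units) apart, within the scatter of two such steps. Adding the methyl to the core of compound 2 gives a 1.6-fold higher number from compound 2 to compound 4 (0.19 log units; within the scatter), so the two cores also read alike with 3-aminophenyl in place: the same change on two cores in this assay, a 1.1-fold higher number (0.03 log units; within the scatter) from compound 1 to compound 3 and a 1.6-fold higher number (0.19 log units; within the scatter) from compound 2 to compound 4, 1.5-fold (0.16 log units) apart, within the scatter of two such steps. This shows transfer only between two cores that differ by one methyl, in one cell line, and does not show that the step would hold on a core that differs more widely, nor what lies behind it.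

On these data alone, it remains open whether the step survives a chlorine or a methoxy in place of that methyl. Also open, as far as these compounds go, is how a hydroxyl or an acetamide would read in place of the amine.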